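Adding a (Methylsulfonyl)methyl Group to Compound 1

A few compounds are considered here, and "the series" means these few. Any claim that something is new, unique, unknown or untested is made for them only; others in the source may bear on it.

Compound 1, `CCC(CC)CNc1c(C(N)=O)cnc2ccc(-c3cccnc3)cc12`: 73 nM
Compound 2, `NC(=O)c1cnc2ccc(-c3cccnc3)cc2c1NC1CCCCC1`: 132 nM
Compound 3, `CCC(CC)CNc1c(C(N)=O)cnc2ccc(-c3ccc(COC)cc3)cc12`: 373 nM

All three were tested in an assay on HT-29 cells for inhibition of Serine-protein kinase ATM (Homo sapiens), read by fluorescence, with a stated time of 1 h (a higher number here means a weaker inhibitor, a lower number a stronger inhibitor), and compound 1 has the lowest number of the three. Compound 2 sits at a 1.8-fold higher number from compound 1 to compound 2 (0.26 log units; within the scatter), while compound 3 is weaker by a 5.1-fold higher number from compound 1 to compound 3 (0.71 log units; beyond the scatter). Compound 4, `CCC(CC)CNc1c(C(N)=O)cnc2ccc(-c3ccc(CS(C)(=O)=O)nc3)cc12`, differs from compound 1 by (methylsulfonyl)methyl in place of hydrogen on an aromatic carbon. For the measured compounds named here, no measured step changes a substituent on the pyridin-3-yl ring itself, so the nearest guide is the step to compound 3, in which the whole aryl group was exchanged and potency fell modestly. A change of at most modest size is therefore expected for compound 4, likely toward a higher number, giving an estimated 2.1-fold higher number from compound 1 to compound 4 (0.31 log units; beyond the scatter). Compound 4 is expected near 150 nM, between 50 nM and 500 nM.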

Compound 4, half-maximal inhibitory concentration: 39 nM
The estimate for compound 4 lay 3.8-fold (0.59 log units) above the measured number, and the stated range ends above it.
By their numbers in this assay, from the lowest: compounds 4, 1 and 2 (each within the scatter of the next, the first and the last beyond it); then compound 3.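

Putting (methylsulfonyl)methyl on an aromatic carbon next to the ring nitrogen and para to a large group gives a 1.9-fold lower number from compound 1 to compound 4 (0.27 log units; within the scatter). For the compounds shown here, this ring position therefore takes a chain of this size with no change beyond the scatter, something the earlier compounds, which left this ring unsubstituted or exchanged it whole, could not show. Nothing available explains this tolerance.

On these data alone, whether a methyl group, an amine or a carboxylic acid would be accepted at this carbon remains open. So does whether (methylsulfonyl)methyl would behave the same way alongside the cyclohexyl group of compound 2.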